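A few compounds are considered here, and "the series" means these few. Any claim that something is new, unique, unknown or untested is made for them only; others in the source may bear on it.

Measured in a functional assay on cardiac atrium (Cavia porcellus); a higher number here means that more compound is needed for the effect, a lower number that less compound is needed:
- compound 1 `CCOC(=O)C1=C(C)NC(C)=C(C(=O)OCC)C1c1c(C(F)(F)F)nc2sccn12`: 1070 nM
- compound 2 `COC(=O)C1=C(C)NC(C)=C(C(=O)OC)C1c1c(-c2ccc(C(F)(F)F)cc2)nc2sccn12`: 120 nM
- compound 3 `CCOC(=O)C1=C(C)NC(C)=C(C(=O)OCC)C1c1c(-c2ccc(C(F)(F)F)cc2)nc2sccn12`: 33 nM

Compound 3, at 33 nM, has the lowest number of the three, with compound 2 next at 120 nM and compound 1 furthest at 1070 nM.

Next is compound 4 `CCOC(=O)C1=C(C)NC(C)=C(C(=O)OCC)C1c1c(-c2ccc(Cl)c(Cl)c2Cl)nc2sccn12`, with 2,3,4-trichlorophenyl in place of 4-(trifluoromethyl)phenyl on an aromatic carbon of a five-membered aromatic ring: 2,3,4-trichlorophenyl in place of 4-(trifluoromethyl)phenyl on an aromatic carbon.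

Among the measured compounds shown here, one measured step bears on this, and only indirectly: a 32-fold lower number from compound 1 to compound 3 (1.51 log units; beyond the scatter), a large step with 4-(trifluoromethyl)phenyl in place of trifluoromethyl. For the measured compounds named here, no measured step compares one substituted phenyl group with another. Both groups here hold one six-membered aromatic ring of carbon only, so a step of that size is not expected. Going by the values given here, with compound 3 at 33 nM, the lowest number so far, a moderate move to a higher number in this assay is the more likely outcome. The expected step is a 2.1-fold higher number from compound 3 to compound 4 (0.33 log units; beyond the scatter), with wide uncertainty. Compound 4 is estimated at 70 nM, within an expected range of 14 nM to 350 nM.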

Compound 4, half-maximal effective concentration: 430 nM
For compound 4 the middle estimate is 6.1-fold (0.79 log units) below the measured one; the whole stated range lies below it.
By their numbers in this assay, from the lowest: compound 3; then compound 2; then compound 4; then compound 1.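

At this position, on an aromatic carbon of a five-membered aromatic ring, this assay shows a large difference between two groups that each hold one six-membered aromatic ring of carbon only, with a 13-fold higher number from compound 3 to compound 4 (1.11 log units; beyond the scatter). The ring alone therefore does not set the number, and 2,3,4-trichlorophenyl keeps only a modest advantage over trifluoromethyl, with a 2.5-fold lower number from compound 1 to compound 4 (0.40 log units; beyond the scatter). No measured evidence on the origin of these differences is available.

On these data alone, compounds 3 and 4 differ in both the halogen and the pattern of substitution on the phenyl ring, so the contribution of each remains open. As far as these compounds go, how a plain phenyl group, or a phenyl ring carrying a single chlorine or an amine, would compare on the same core also remains open.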